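The compounds below may be only part of what the source reports. "The series", "measured", "known", "first", "only" and "open" are said of these compounds alone.

Compound 1 `CCOC(=O)[C@H](C)NC(=O)/C=C/c1ccc(O)c(O)c1`: 214000 nM
Compound 2 `CCOC(=O)CNC(=O)/C=C/c1ccc(O)c(O)c1`: 340000 nM
Compound 3 `CCOC(=O)[C@@H](NC(=O)/C=C/c1ccc(O)c(O)c1)C(C)C`: 348000 nM

In a functional assay, read by spectrophotometry, with a stated time of 1 h (a lower number here means a stronger inhibitor, a higher number a weaker inhibitor), compound 3 stands at the highest of the three numbers, but its gaps to compound 2 and to compound 1 both lie within the scatter, so no ranking among the three is drawn. Compound 4 `CCOC(=O)[C@H](CC(C)C)NC(=O)/C=C/c1ccc(O)c(O)c1` carries isobutyl in place of isopropyl on a saturated chain carbon bound to an amide-type nitrogen and a carbonyl carbon. The measured steps that bear on this position are a 1.6-fold higher number from compound 1 to compound 3 (0.21 log units; within the scatter), a 1.0-fold higher number from compound 2 to compound 3 (0.01 log units; within the scatter) and a 1.6-fold higher number from compound 1 to compound 2 (0.20 log units; within the scatter), none of them beyond the scatter. A further change of the group on the same carbon is therefore expected to give no step beyond the scatter in this assay, a 1.0-fold lower number from compound 3 to compound 4 (0.01 log units; within the scatter). Compound 4 is estimated at 340000 nM, with a range from 150000 nM to 750000 nM.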

Compound 4, half-maximal inhibitory concentration: 373000 nM
Beside the measured number, compound 4's estimate is 1.1-fold (0.04 log units) below it, within the range that was stated.
By their numbers in this assay, from the lowest: compounds 1, 2, 3 and 4 (each within the scatter of the next).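

In this assay isobutyl on this saturated chain carbon gives a 1.1-fold higher number from compound 3 to compound 4 (0.03 log units; within the scatter) and a 1.1-fold higher number from compound 2 to compound 4 (0.04 log units; within the scatter) and a 1.7-fold higher number from compound 1 to compound 4 (0.24 log units; within the scatter) in the series. Hydrogen, methyl, isopropyl and isobutyl thus set no compound of the four apart at this position. The change also reads alike on two cores: the same change on two cores in this assay, a 1.0-fold higher number (0.01 log units; within the scatter) from compound 2 to compound 3 and a 1.7-fold higher number (0.24 log units; within the scatter) from compound 1 to compound 4, 1.7-fold (0.23 log units) apart, within the scatter of two such steps.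

Going by these compounds, whether a benzyl group or a chain ending in an amine on this carbon would give a step beyond the scatter stays open. The same holds for a carboxylic acid in place of the ethyl ester.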